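Moving a methyl around the phenoxy ring

A few compounds are considered here, and "the series" means these few. Any claim that something is new, unique, unknown or untested is made for them only; others in the source may bear on it.

Compound 3 `Cc1ccccc1Oc1cc(F)cc(N2Cc3ccccc3S2(=O)=O)c1` sits at the top of the three numbers as written: in a functional assay on Flp-In T-REx293 cells for antagonist activity at Free fatty acid receptor 1 (Homo sapiens), read by calcium flux (on this read-out higher numbers stand for larger maximal responses and lower numbers for smaller maximal responses), compound 3 gives 71%. Compound 2 `CCCCc1ccc(NS(=O)(=O)c2ccc(F)cc2)cc1` gives 68% in this assay, a number that lies within the usual scatter of compound 3, so the two cannot be told apart. Compound 1 `O=S1(=O)c2ccccc2CN1c1cc(F)cc(OCc2ccccc2)c1` gives 36% in this assay, well below both. Within the data shown here, the only measured step that touches this series, a number 35 percentage points higher from compound 1 to compound 3 (beyond the scatter), swaps a benzyl for a 2-methylphenyl on the oxygen and is large.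

Compound 4 `Cc1cccc(Oc2cc(F)cc(N3Cc4ccccc4S3(=O)=O)c2)c1` differs from compound 3 by 3-methylphenyl in place of 2-methylphenyl on an oxygen on an aromatic ring. Among the measured compounds shown here, no measured pair moves a methyl from one position of this ring to another, so the step from compound 1 to compound 3 bears on it only loosely: it shows that the group on the oxygen matters, not how the methyl's position matters. For the measured compounds named here, with no direct precedent, the expected step of a number 3 percentage points lower from compound 3 to compound 4 (within the scatter) is none beyond the scatter. Compound 4 is therefore estimated at 68% in this assay, within a range of 50% to 85%.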

Compound 4, largest response reached (reported as Imax), in percent of the reference or control that the assay uses: 51%
Compound 4: middle estimate off by 17 percentage points, on the high side; the range from low to high includes it.
By their numbers in this assay, from the lowest: compound 1; then compound 4; then compounds 2 and 3 (each within the scatter of the next).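

Shifting only the methyl on the phenoxy ring gives a number 20 percentage points lower from compound 3 to compound 4 (beyond the scatter) in this assay and so shows that the methyl's position matters, even though the two groups hold the same atoms. The step from benzyl could not show this, since it changed the whole group on the oxygen. The 3-methylphenyl group still gives a number 15 percentage points higher from compound 1 to compound 4 (beyond the scatter) and so, like 2-methylphenyl, reads higher than benzyl, though by a smaller step. Nothing shown here explains why the position counts.

Open, going by these compounds, is whether 4-methylphenyl or plain phenyl on the oxygen would read closer to compound 3 or to compound 4. Also open, on these data alone, is whether the same methyl shift would give a similar step with chlorine in place of the fluorine.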